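This account rests on a few compounds, and the source may have more. Where it says the series, first, only, none or still open, it means among the compounds named here.

Compound 1 `COc1ccc(-c2nc3cc(NC(=O)[C@H](C)Oc4cccc(F)c4F)ccc3o2)cc1` is a member of a small set tested in an assay on isolated protein for inhibition of GMP reductase 2 (Homo sapiens), read by spectrophotometry; a higher number here means a weaker inhibitor, a lower number a stronger inhibitor. In this assay compound 1 gives > 5000 nM, which is a limit of the measurement rather than a number. Its neighbour compound 2 `COc1ccc(-c2nc3cc(NC(=O)[C@H](C)Oc4ccccc4CN)ccc3o2)cc1` carries 2-(aminomethyl)phenyl in place of 2,3-difluorophenyl on an oxygen on a saturated carbon; in this assay compound 2 gives > 5000 nM, again a limit and not a number. Going by the values given here, the step that the two limits leave unreadable from compound 1 to compound 2 therefore cannot be sized, and the only evidence so far is the limit of > 5000 nM in this assay, at which 2 of the 2 values shown sit.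

Compound 3 `C[C@H](Oc1cccc(F)c1F)C(=O)Nc1ccc2oc(-c3ccc(F)cc3)nc2c1` is not yet measured. It differs from compound 1 by fluoro in place of methoxy on an aromatic carbon; cut one bond further out, the change reads 4-methoxyphenyl to 4-fluorophenyl. Among the compounds with values here, no measured step touches this position, and the one step that exists, from compound 1 to compound 2, is unreadable. With both measured compounds at the limit, no direction can be read. Compound 3 is expected to stay near that limit, with an estimated step that the limit leaves unreadable from compound 1 to compound 3, and an expected inhibition constant of 8000 nM, in the range 2500 nM to 30000 nM. The measured value for compound 3 in this assay follows.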

Compound 3, inhibition constant: > 5000 nM
Compound 3: no number, only a limit; the forecaster's own chance of this, stated with the estimate: 80%; the middle value does not contradict the limit.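

In this assay, going by these compounds alone, compound 3 gives > 5000 nM, a limit and not a number, so no step between compound 1 and compound 3 can be read, and the evidence remains only this: the limit of > 5000 nM in this assay, at which 3 of the 3 values shown sit. The compounds shown leave open what the actual inhibition constant of any of the three is, and which change would bring one within measurable range.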